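Removing the basic ring from a benzyl position

This account rests on a few compounds, and the source may have more. Where it says the series, first, only, none or still open, it means among the compounds named here.

Measured so far in a functional assay on KG-1a cells (Homo sapiens) for inhibition, read by MTT assay, with a stated time of 72 h; on this read-out lower numbers stand for stronger inhibition and higher numbers for weaker inhibition:
Compound 1 `Cc1ccc(-c2cn(-c3ccc(CN4CCCCC4)cc3)nn2)cc1Nc1nccc(-c2cccnc2)n1` gives 1750 nM.
Compound 2 `Cc1ccc(-c2nnc(-c3ccc(CN4CCN(C)CC4)cc3)o2)cc1Nc1nccc(-c2cccnc2)n1` gives 1780 nM.
Compound 3 `Cc1ccc(-c2nnc(-c3ccc(CN4CCN(C)CC4)c(C(F)(F)F)c3)o2)cc1Nc1nccc(-c2cccnc2)n1` gives 580 nM.

Compound 3 carries the lowest number of the three, and its nearest neighbour is compound 1. Within the data shown here, the single measured step, a 3.1-fold lower number from compound 2 to compound 3 (0.49 log units; beyond the scatter), concerns a trifluoromethyl group and says nothing about the change considered here. Compound 4 `Cc1ccc(-c2nnc(-c3ccc(C)c(C(F)(F)F)c3)o2)cc1Nc1nccc(-c2cccnc2)n1` differs from compound 3 by hydrogen in place of 4-methylpiperazin-1-yl on a saturated chain carbon bound to an aromatic carbon. Among the measured compounds shown here, no measured pair shows this change, so the expectation rests on no direct precedent. With the group simply removed, a modest weakening is expected, a 2.1-fold higher number from compound 3 to compound 4 (0.32 log units; beyond the scatter), but the uncertainty is wide. For compound 4 the estimate in this assay is 1200 nM, within a range from 400 nM to 4000 nM.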

Compound 4, half-maximal inhibitory concentration: > 30000 nM
Compound 4: only a limit was reported; the forecaster's own chance of this, stated with the estimate: 5%; middle value at least 25-fold (1.39 log units) from the limit.
By their numbers in this assay, from the lowest: compound 3; then compounds 1 and 2 (each within the scatter of the next). At a limit, above all of these: compound 4.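

In this assay, cutting (4-methylpiperazin-1-yl)methyl back to methyl gives an at least 51-fold higher number from compound 3 to compound 4 (1.71 log units; beyond the scatter). The value for compound 4 is a limit of the assay, not a number: the limit of > 30000 nM in this assay, at which 1 of the 4 values shown sits. Compounds 1, 2 and 3 all keep a saturated ring on this carbon, so only compound 4 shows that, with trifluoromethyl kept, the activity in this assay depends heavily on the group lost here.

The compounds shown leave open whether a dimethylamine or a morpholine ring on this carbon would restore activity. They also cannot separate the part played by the ring from that of its nitrogen atoms.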